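The compounds below may be only part of what the source reports. "The series", "measured", "known", "first", "only" and "open" are said of these compounds alone.

Measured so far in a functional assay on SMMC-7721 cells (Homo sapiens) for cytotoxicity, read by MTT assay, with a stated time of 48 h; on this read-out higher numbers stand for weaker inhibition and lower numbers for stronger inhibition:
compound 1, `CCOC(=O)[C@@H]1C[C@@]23CN(C)C[C@@H](CCC4=C2[C@H]1CC4=O)C31CC[C@](CC)(OC)OC1`: > 40000 nM
compound 2, `CCO[C@@]1(CC)CCC2(CO1)[C@@H]1CCC3=C4[C@@H](CC3=O)[C@H](C(=O)OC)C[C@@]42CN(C)C1`: > 40000 nM
compound 3, `CC[C@@]1(OC)CCC2(CO1)[C@@H]1CCC3=C4[C@H](CC3=O)[C@H](C(=O)OC)C[C@@]42CN(C)C1`: > 40000 nM.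

For compound 1 the value is only a limit of this assay, > 40000 nM. Compound 2 also reaches only the limit, > 40000 nM. Compound 3 stands at the same limit, > 40000 nM, so no number places it among the others; all three sit where the limit of > 40000 nM in this assay, at which 3 of the 3 values shown sit, describes. Compound 4, `CC[C@]1(OC)CCC2(CO1)[C@@H]1CCC3=C4[C@@H](CC3=O)[C@H](C(=O)OC)C[C@@]42CN(C)C1`, shares every atom and bond with compound 3 and differs only in configuration: the two compounds have the same atoms and bonds; at least one stereo element is drawn with a configuration in one of them and without one in the other: 2 of 6 stereo elements differ; a stereocentre at a saturated ring carbon is drawn S in compound 3 and R in compound 4; a stereocentre at a saturated ring carbon is drawn R in compound 3 and S in compound 4. No step between measured compounds exists here, and nothing shown separates the three stereoisomers. The expected step that the limit leaves unreadable from compound 3 to compound 4 is therefore small, most likely none beyond the scatter, with compound 4 also expected to sit at a limit. Compound 4 is estimated at 60000 nM, between 20000 nM and 200000 nM.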

Compound 4, half-maximal inhibitory concentration: > 40000 nM
Compound 4: a limit, no number (the forecaster's own chance of this, stated with the estimate: 85%); the middle value does not contradict the limit.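

In this assay compound 4 gives > 40000 nM and this is a limit, not a number. Its steps from compound 1, compound 2 and compound 3 cannot be read: the limit of > 40000 nM in this assay, at which 4 of the 4 values shown sit. The compounds shown leave open whether the configuration or the alkyl groups on the oxygen change cytotoxicity at all.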